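Swapping the acyl group on the shared core

The source may report more compounds than this note shows. Statements on the series, on what has been measured and on what is new or still open speak of the compounds shown alone.

Compound 1 `O=C(OC1CC1)N1CCc2nc(C3(C(=O)Nc4ccc(Cl)cc4)CCC3)ccc21`: 2 nM
Compound 2 `O=C(c1cccc(Cl)c1)N1CCc2nc(C3(C(=O)Nc4ccc(F)cc4)CCC3)ccc21`: 3 nM

In an assay on HeLa cells for inhibition of Indoleamine 2,3-dioxygenase 1 (Homo sapiens) (a higher number here means a weaker inhibitor, a lower number a stronger inhibitor), compound 1 gives 2 nM. In this assay compound 2 gives 3 nM. Compound 2 has the higher of the two numbers shown, but its nearest neighbour on the scale, compound 1, sits within the usual scatter of it, so the two values cannot be told apart, and no ordering of the pair is claimed.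

Compound 3 `O=C(OC1CC1)N1CCc2nc(C3(C(=O)Nc4ccc(F)cc4)CCC3)ccc21` has not yet been measured. It differs from compound 2 in one place: cyclopropyloxy in place of 3-chlorophenyl on a carbonyl carbon. The rest of the molecule, including the amide to the fluorophenyl ring and the shared core, is unchanged. Compound 1 carries this same cyclopropyloxycarbonyl group together with a chlorophenyl amide and gives 2 nM, so the group is already represented among the measured compounds at a low number.

For the measured compounds named here, with no measured step between compounds that differ in this one place, the expectation rests on the two values alone. Compound 3 is expected to move by a 1.5-fold lower number from compound 2 to compound 3 (0.18 log units; within the scatter), a change not expected to exceed the scatter. Compound 3 is estimated at 2 nM, with a range from 0.8 nM to 6 nM.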

Compound 3, half-maximal inhibitory concentration: 2.7 nM
Compound 3: middle estimate off by 1.4-fold (0.13 log units), on the low side, and the stated range covers the measured number.
By their numbers in this assay, from the lowest: compounds 1, 3 and 2 (each within the scatter of the next).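

For the compounds shown here, compound 3 gives the first direct reading of the place on the carbonyl carbon attached to the amide-type nitrogen in a ring: in this assay, cyclopropyloxy in place of 3-chlorophenyl gives a 1.1-fold lower number from compound 2 to compound 3 (0.05 log units; within the scatter). So this exchange of a six-membered aromatic ring of carbon for a three-membered non-aromatic ring of carbon, with one hydrogen-bond acceptor entering, does not separate the pair in this assay. Compound 3 also gives a reading of a second place, where fluoro in place of chloro on an aromatic carbon gives a 1.4-fold higher number from compound 1 to compound 3 (0.13 log units; within the scatter), so neither single change moves the number beyond the scatter.

Nothing available on these compounds bears on what lies behind this result. Still open, going by these compounds, is whether the number would hold with a piperidine or a longer alkoxy chain on that carbonyl carbon, or with a methoxy group in place of the fluoro on the aromatic carbon.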